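Replacing a urea with a dichlorobenzamide on a shared core

The compounds below may be only part of what the source reports. "The series", "measured", "known", "first", "only" and "open" are said of these compounds alone.

Measured compounds:
compound 1 `COc1cc(-c2nn(-c3ccc(NC(=O)Nc4ccc(Cl)c(C(F)(F)F)c4)cc3)cc2-c2ccncc2)ccc1Cl` gives 1630 nM
compound 2 `O=C(Nc1ccc(-n2cc(-c3ccncc3)c(-c3ccc(Cl)c(O)c3)n2)cc1)Nc1ccc(Cl)c(C(F)(F)F)c1` gives 1700 nM

Both numbers come from a functional assay on SK-MEL-2 cells (Homo sapiens) for antiproliferative activity, read by sulforhodamine B assay, with a stated time of 48 h; on this read-out higher numbers stand for weaker inhibition and lower numbers for stronger inhibition. In this assay compound 2 gives 1700 nM, and compound 1 gives 1630 nM; the two values lie within the scatter of each other, so neither can be told apart from the other. Among the measured compounds shown here, the only measured step, a 1.0-fold higher number from compound 1 to compound 2 (0.02 log units; within the scatter), concerns a change on an oxygen on an aromatic ring and says nothing about the part of the molecule altered next.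

Compound 3 `O=C(Nc1ccc(-n2cc(-c3ccncc3)c(-c3ccc(Cl)c(O)c3)n2)cc1)c1cc(Cl)cc(Cl)c1` differs from compound 2 in that part: 3,5-dichlorophenyl in place of (4-chloro-3-(trifluoromethyl)phenyl)amino on a carbonyl carbon. For the measured compounds named here, no measured step bears on this exchange, so the expectation rests only on the two numbers above and on the size of the change. Compound 3 is therefore estimated at 3000 nM, with a range from 800 nM to 12000 nM. This means an expected step of a 1.8-fold higher number from compound 2 to compound 3 (0.25 log units; within the scatter), and the true step could fall on either side of it.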

Compound 3, half-maximal inhibitory concentration: 6910 nM
For compound 3 the middle estimate is 2.3-fold (0.36 log units) below the measured one, within the range that was stated.
By their numbers in this assay, from the lowest: compounds 1 and 2 (each within the scatter of the next); then compound 3.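

In this assay, exchanging (4-chloro-3-(trifluoromethyl)phenyl)amino for 3,5-dichlorophenyl on the carbonyl carbon gives a 4.1-fold higher number from compound 2 to compound 3 (0.61 log units; beyond the scatter) and thus shows that this end of the molecule, unlike the oxygen changed earlier, can shift the read-out. Among the compounds shown here, the single exchange alters several things at once: the leaving group's hydrogen-bond donor is gone, the heavy-atom count falls, and the ring carries different substituents, so the step cannot be assigned to any one of them. Nothing available here gives a reason for the weaker inhibition.

Still open, on these data alone, is whether the urea or the ring substituents carry the step, and a urea bearing 3,5-dichlorophenyl would separate the two. As far as these compounds go, how an amine or a carboxylic acid on that ring would read also remains open.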